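A few compounds are considered here, and "the series" means these few. Any claim that something is new, unique, unknown or untested is made for them only; others in the source may bear on it.

Compound 1 `O=[N+]([O-])c1cn2c(n1)[S@@+]([O-])C[C@@H](OCc1ccc(OC(F)(F)F)cc1)C2` is a single drawn stereoisomer of the series. In an ADME assay on L929 cells (Mus musculus) for cytotoxicity (a lower number here means a stronger inhibitor, a higher number a weaker inhibitor), compound 1 gives only a limit, > 10 ug/mL. Compound 2 `CN1CC(OCc2ccc(OCc3ccccc3)cc2)Cn2nc([N+](=O)[O-])cc21` is the other measured member. In this assay compound 2 likewise gives only a limit, > 10 ug/mL. Compound 1 therefore stands at the limit of > 10 ug/mL in this assay, at which 2 of the 2 values shown sit, with no resolved number anywhere. Compound 3 `O=[N+]([O-])c1cn2c(n1)[S+]([O-])CC(OCc1ccc(OC(F)(F)F)cc1)C2` differs from compound 1 as follows: the two compounds have the same atoms and bonds; at least one stereo element is drawn with a configuration in one of them and without one in the other: 2 of 2 stereo elements differ; a stereocentre at a sulfur is drawn S in compound 1 and without a configuration in compound 3; a stereocentre at a saturated ring carbon is drawn S in compound 1 and without a configuration in compound 3. For the measured compounds named here, with no measured step to lean on, the step from compound 1 to compound 3 is expected to be no more than the scatter, a step that the limit leaves unreadable from compound 1 to compound 3. Compound 3 is estimated at 20 ug/mL, between 8 ug/mL and 60 ug/mL, most likely reported again as a limit.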

Compound 3, half-maximal inhibitory concentration: > 10 ug/mL
Compound 3 gave a limit, no number (the forecaster's own chance of this, stated with the estimate: 85%); the middle value is on the limit's open side.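

No step can be read between compound 1 and compound 3 in this assay, since both give only a limit: the limit of > 10 ug/mL in this assay, at which 3 of the 3 values shown sit.

From the compounds shown here alone, whether the configuration at the sulfur or at the saturated ring carbon matters stays open, as does a resolved number for compound 1, compound 2 or compound 3.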